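A few compounds are considered here, and "the series" means these few. Any claim that something is new, unique, unknown or untested is made for them only; others in the source may bear on it.

Compound 1, whose structure is `Nc1cc(N)c2nc(-c3ccccc3)c(Oc3ccc(Cl)c(Cl)c3)nc2c1`, sets the starting point. In a functional assay on UO-31 cells (Homo sapiens) for inhibition, read by sulforhodamine B assay, with a stated time of 48 h (on this read-out higher numbers stand for weaker inhibition of growth and lower numbers for stronger inhibition of growth), compound 1 gives 4070 nM, the lowest of the two full numbers available. Compound 3, with the structure `CCOC(=O)[C@H](CCC(=O)O)NC(=O)c1ccc(Sc2nc3cc(N)cc(N)c3nc2-c2ccccc2)cc1`, gives 28200 nM in this assay, a weaker inhibition of growth that lies beyond the usual scatter when set against compound 1. Compound 2, with the structure `CCOC(=O)[C@H](CCC(=O)O)NC(=O)c1ccc(CNc2nc3cc(N)cc(N)c3nc2-c2ccccc2)cc1`, returns only a limit in this assay, < 100000 nM, which says merely that the measurement did not reach a number: the limit of < 100000 nM in this assay, at which 1 of the 3 values shown sits. Compound 4, with the structure `Nc1cc(N)c2nc(-c3ccccc3)c(NCc3ccc(F)cc3)nc2c1`, has not yet been measured. It differs from compound 1 in a single place: (4-fluorobenzyl)amino in place of 3,4-dichlorophenoxy on an aromatic carbon. For the measured compounds named here, no measured pair shows this exact change on the shared core, so the direction can only be estimated from what is known. The amino-linked compound 2 gave only a limit in this assay. The sulfur-linked compound 3 gave 28200 nM, a weaker inhibition of growth than compound 1, and on that basis the expected step, a 2.9-fold higher number from compound 1 to compound 4 (0.47 log units; beyond the scatter), is toward weaker inhibition, beyond the scatter. Compound 4 is therefore expected to give about 12000 nM in this assay, most likely between 2500 nM and 60000 nM.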

Compound 4, concentration for 50% growth inhibition: 3800 nM
Compound 4: the middle estimate sits 3.2-fold (0.50 log units) above what was measured, and the stated range covers the measured number.
By their numbers in this assay, from the lowest: compounds 4 and 1 (each within the scatter of the next); then compound 3.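

In this assay, putting (4-fluorobenzyl)amino in place of 3,4-dichlorophenoxy on this aromatic carbon, next to the ring nitrogen and ortho to a phenyl group, amounts to a 1.1-fold lower number from compound 1 to compound 4 (0.03 log units; within the scatter), a difference that lies within the scatter. For the compounds shown here, this position therefore accepts either of these two groups with no measurable change in growth inhibition, even though the entering group brings a hydrogen-bond donor that the leaving group lacks, and compound 4 supplies the first full number for a nitrogen-linked group on this core. The earlier nitrogen-linked compound 2 offered only a limit, not a number, and so could not show this: the limit of < 100000 nM in this assay, at which 1 of the 4 values shown sits.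

The linking atom and the groups on the outer ring change together in this single step, so the compounds shown cannot say what each contributes on its own. A plain benzylamino group, a 3,4-dichlorobenzylamino group or a longer chain such as 2-phenylethylamino would help separate these contributions and show how far this position's tolerance extends.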